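A few compounds are considered here, and "the series" means these few. Any claim that something is new, unique, unknown or untested is made for them only; others in the source may bear on it.

Compound 3 `Cc1cc(S(N)(=O)=O)ccc1NC(=O)COc1ccc2cc(Br)ccc2c1C(=O)c1ccccc1` gives the smallest of the three numbers in an ADME assay on C8166 cells (Homo sapiens) for cytotoxicity, read by colorimetric assay and MTT assay (a higher number here means that more compound is tolerated, a lower number that less compound is tolerated), at 29200 nM, though all three lie within the scatter of one another: compound 1 `Cc1cc(S(N)(=O)=O)ccc1NC(=O)COc1ccc2ccccc2c1C(=O)c1ccccc1` gives 33800 nM and compound 2 `Cc1cc(S(N)(=O)=O)ccc1NC(=O)COc1ccc2ccccc2c1C(=O)c1cc(Cl)cc(C#N)c1` gives 49400 nM. Compound 4 `Cc1cc(S(N)(=O)=O)ccc1NC(=O)COc1ccc2cc(Br)ccc2c1C(=O)c1cccc(F)c1` differs from compound 3 by fluoro in place of hydrogen on an aromatic carbon. Going by the values given here, no measured pair tests a single halogen on that benzoyl ring. The nearest comparisons are a 1.5-fold higher number from compound 1 to compound 2 (0.16 log units; within the scatter), a larger change on the same ring, and a 1.2-fold lower number from compound 1 to compound 3 (0.06 log units; within the scatter), a halogen on the shared core. Both stay within the scatter, so no step beyond the scatter in this assay is expected in either direction. Compound 4 is therefore estimated at 30000 nM, with a range from 15000 nM to 60000 nM. The expected step is a 1.0-fold higher number from compound 3 to compound 4 (0.01 log units; within the scatter).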

Compound 4, half-maximal cytotoxic concentration: 31000 nM
Compound 4: the middle estimate sits 1.0-fold (0.01 log units) below what was measured, within the range that was stated.
By their numbers in this assay, from the lowest: compounds 3, 4, 1 and 2 (each within the scatter of the next).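

In this assay, going by these compounds alone, fluoro in place of hydrogen, meta to a large group on the benzoyl ring, gives a 1.1-fold higher number from compound 3 to compound 4 (0.03 log units; within the scatter) and so supplies the direct single-halogen reading on that ring that the earlier steps lacked. The bromo compound tolerates this change without a step beyond the scatter, as the compound without bromo did with the larger 1.5-fold higher number from compound 1 to compound 2 (0.16 log units; within the scatter) on the same ring. No evidence on why bears on this result. Still open, from the compounds shown here alone, is whether an amine or a carboxylic acid at this position would give a step beyond the scatter in this assay as well.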